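Swapping the benzoyl group for an acetoacetyl chain

The source may report more compounds than this note shows. Statements on the series, on what has been measured and on what is new or still open speak of the compounds shown alone.

Measured compounds:
compound 1 `N#CC1=C(NC(=O)c2ccccc2)N(c2ccc(S(N)(=O)=O)cc2)C2=C(C(=O)CCC2)C1c1ccc(Cl)cc1Cl` gives 60%
compound 2 `CN(C)c1ccc(/C=C/C=N/C2=C(C#N)C(c3ccc(Cl)cc3Cl)C3=C(CCCC3=O)N2c2ccc(S(N)(=O)=O)cc2)cc1` gives 20%
compound 3 `N#CC1=C(/N=C/c2ccc([N+](=O)[O-])cc2[N+](=O)[O-])N(c2ccc(S(N)(=O)=O)cc2)C2=C(C(=O)CCC2)C1c1ccc(Cl)cc1Cl` gives 20%

In a functional assay on Ehrlich cells (Mus musculus) for cytotoxicity, read by trypan blue exclusion, with a stated time of 2 h, tested at 25 ug/mL (on this read-out lower numbers stand for a weaker effect and higher numbers for a stronger effect at the one concentration tested), compound 1 stands highest of the three numbers, with compound 2 and compound 3 both well lower. Compound 4 `CC(=O)CC(=O)NC1=C(C#N)C(c2ccc(Cl)cc2Cl)C2=C(CCCC2=O)N1c1ccc(S(N)(=O)=O)cc1` is the unmeasured analogue of compound 1, with the change (2-oxopropyl in place of phenyl on a carbonyl carbon). Among the measured compounds shown here, the only measured step, no change at the digits printed from compound 2 to compound 3 (within the scatter), changes a group on the imine carbon, not the amide carbonyl, so no measured step bears directly on this change. Without a guide, the expectation is a step of about a number 15 percentage points lower from compound 1 to compound 4 (beyond the scatter) from compound 1, leaning slightly toward the lower values seen in compound 2 and compound 3. Compound 4 is therefore estimated at 45%, within the range 20% to 70%.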

Compound 4, a percentage reported as activity, at one concentration (the size of the read-out at that concentration, not a potency): 44%
The estimate for compound 4 lay 1 percentage points above the measured number, and the stated range covers the measured number.
By their numbers in this assay, from the lowest: compounds 2 and 3 (each within the scatter of the next); then compound 4; then compound 1.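

In this assay, putting 2-oxopropyl in place of phenyl on this carbonyl carbon gives a number 16 percentage points lower from compound 1 to compound 4 (beyond the scatter). The phenyl ring therefore helps the read-out at this position but is not required for it, since compound 4, with no ring in that group, still gives 44%. Nothing available explains the size of this drop. Still open, on these data alone, is how a plain methyl, a longer alkyl chain or a carboxylic acid would read on this carbonyl carbon. Such groups could show whether the step follows from losing phenyl or from the ketone carbonyl in 2-oxopropyl.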